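Shortening the alkynyl chain of compound 3 by ethyl

This account rests on a few compounds, and the source may have more. Where it says the series, first, only, none or still open, it means among the compounds named here.

Measured in a functional assay on HEL cells (Homo sapiens) for cytotoxicity; on this read-out lower numbers stand for higher toxicity in this test and higher numbers for lower toxicity in this test:
Compound 1 `CCCCC#Cc1cc2cn([C@@H]3O[C@H](CO)[C@@H](O)[C@H]3O)c(=O)nc2o1`: a limit of this assay, > 144000 nM
Compound 2 `CCCCCCCCC#Cc1cc2cn([C@@H]3O[C@H](CO)[C@@H](O)[C@@H]3O)c(=O)nc2o1`: 49000 nM
Compound 3 `CCCCCCCCCCC#Cc1cc2cn([C@@H]3O[C@H](CO)[C@@H](O)[C@H]3O)c(=O)nc2o1`: 12000 nM

Compound 3 stands lowest of the two numbers that were obtained; the nearest number is that of compound 2, which lies beyond the scatter above it, while compound 1 is known only as a limit (the limit of > 144000 nM in this assay, at which 1 of the 3 values shown sits). Among the measured compounds shown here, the step from compound 1 to compound 3 is the one measured change at the chain: an at least 12-fold lower number from compound 1 to compound 3 (1.07 log units; beyond the scatter). The unmeasured compound 4 `CCCCCCCCC#Cc1cc2cn([C@@H]3O[C@H](CO)[C@@H](O)[C@H]3O)c(=O)nc2o1` differs from compound 3 by hydrogen in place of ethyl on a saturated chain carbon, eight bonds along the chain from a triple-bonded carbon. This runs the chain in the opposite direction from that step, so a rise in the number, smaller than that step because the measured step of an at least 12-fold lower number from compound 1 to compound 3 (1.07 log units; beyond the scatter) covers the removal of hexyl while here only ethyl is removed, is expected: a 3.3-fold higher number from compound 3 to compound 4 (0.52 log units; beyond the scatter). Compound 4 is therefore expected to give 40000 nM in this assay, within a range from 15000 nM to 110000 nM.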

Compound 4, minimum cytotoxic concentration: 49000 nM
Compound 4: middle estimate off by 1.2-fold (0.09 log units), on the low side; measured number inside the range.
By their numbers in this assay, from the lowest: compound 3; then compounds 2 and 4 (each within the scatter of the next). At a limit, above all of these: compound 1.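

In this assay, the loss of ethyl alone, on a saturated chain carbon, eight bonds along the chain from a triple-bonded carbon, is enough to move the number: a 4.1-fold higher number from compound 3 to compound 4 (0.61 log units; beyond the scatter). Compound 4 also separates from the shortest chain shown, with an at least 2.9-fold lower number from compound 1 to compound 4 (0.46 log units; beyond the scatter), so the number falls along compounds 1, 4 and 3 as the chain grows, though this step is bounded on one side by a limit: the limit of > 144000 nM in this assay, at which 1 of the 4 values shown sits. The configuration at a saturated ring carbon leaves no mark at this chain length, with no change at the digits printed from compound 2 to compound 4 (within the scatter): the fact that compounds 2 and 4 differ only in the configuration as drawn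

Going by these compounds, whether the number keeps falling with a longer chain than that of compound 3, or how an amine or a carboxylic acid would read in that place, stays open. Also open, on these data alone, is whether the configuration at that ring carbon is equally silent at other chain lengths.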